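The source may report more compounds than this note shows. Statements on the series, on what has been measured and on what is new or still open speak of the compounds shown alone.

Of the compounds shown here, three built on one shared core have been tested in a functional assay on K562 cells (Homo sapiens) for inhibition, read by trypan blue exclusion, with a stated time of 72 h; on this read-out higher numbers stand for weaker inhibition and lower numbers for stronger inhibition. Compound 1 `Cn1c(=O)c(S(=O)(=O)c2ccc(F)cc2F)cc2cnc(Nc3cccc4[nH]ccc34)nc21` gives 1500 nM; compound 2 `Cn1c(=O)c(S(=O)(=O)c2ccc(C(=O)O)cc2)cc2cnc(Nc3ccc4[nH]ccc4c3)nc21` gives 5000 nM; compound 3 `Cn1c(=O)c(S(=O)(=O)c2ccc(F)cc2F)cc2cnc(Nc3ccc4c(c3)CC(=O)N4)nc21` gives 15000 nM. Compound 2 thus holds the second highest of the three numbers, closer to compound 3 than to compound 1. For the measured compounds named here, the only single-point step among them, a 10-fold higher number from compound 1 to compound 3 (1.00 log units; beyond the scatter), concerns the group on a nitrogen on an aromatic ring, not the ring where compound 4 differs. Compound 4 `Cn1c(=O)c(S(=O)(=O)c2ccc(Br)cc2)cc2cnc(Nc3ccc4[nH]ccc4c3)nc21` is compound 2 with one change: bromo in place of carboxy on an aromatic carbon. Going by the values given here, no measured step touches this part of the molecule, so there is no direct guide, and only a small shift in this assay, if any, is expected. Compound 4 is estimated at 2500 nM, within 600 nM to 10000 nM. That is an expected step of a 2.0-fold lower number from compound 2 to compound 4 (0.30 log units; within the scatter).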

Compound 4, half-maximal inhibitory concentration: 5000 nM
Compound 4: middle estimate off by 2.0-fold (0.30 log units), on the low side, within the range that was stated.
By their numbers in this assay, from the lowest: compound 1; then compounds 2 and 4 (each within the scatter of the next); then compound 3.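

In this assay, for the compounds shown here, the change from 4-carboxyphenyl to 4-bromophenyl gives no change at the digits printed from compound 2 to compound 4 (within the scatter) and is the first measured step at this position. This read-out therefore does not separate carboxy from bromo here, although the two differ in heavy atoms and in hydrogen-bond donors and acceptors. Nothing available explains this result. The compounds shown leave open whether an amine, a methoxy group or a longer chain at this position would shift the number. They also leave open whether the same swap would read alike with a different group on the nitrogen.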